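A few compounds are considered here, and "the series" means these few. Any claim that something is new, unique, unknown or untested is made for them only; others in the source may bear on it.

The series shares a core in which an aryl piperazine amide is joined to a five-membered heterocycle, and potency was followed in a functional assay on HL-60 cells (Homo sapiens) for inhibition, read by MTT assay, with a stated time of 72 h; on this read-out higher numbers stand for weaker inhibition and lower numbers for stronger inhibition. Compound 1 `Cc1nc(-c2ccccc2)c(C(=O)N2CCN(c3ccc(C(F)(F)F)cc3)CC2)o1` is reported in this assay only as a limit, > 1000 nM, and no single number is given. Its place in the set is thus set by the limit of > 1000 nM in this assay, at which 1 of the 3 values shown sits, rather than by a measured figure. Compound 2 `CCCc1nc(-c2ccc(OC)c(OC)c2)c(C(=O)N2CCN(c3cccc(Cl)c3)CC2)o1` is entered in this assay as "not active" (no number reported), again without a number. For the measured compounds named here, compound 3 `COc1cc(OC)cc(N2CCN(C(=O)c3onc(C)c3-c3ccc(F)cc3)CC2)c1` is the one compound with a figure, giving 475 nM in this assay.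

Compound 4 `Cc1nc(-c2ccccc2)c(C(=O)N2CCN(c3ccccc3C(F)(F)F)CC2)o1` has not yet been measured in this assay. It differs from compound 1 by 2-(trifluoromethyl)phenyl in place of 4-(trifluoromethyl)phenyl on an amine nitrogen in a ring. No step between measured compounds is shown for this assay, so there is nothing to gauge the size of such a change against, and compound 1 itself carries only a limit. Compound 4 is therefore expected to stay near the limit, with a step that the limit leaves unreadable from compound 1 to compound 4, and its estimated value is 2000 nM, within a range from 700 nM to 6000 nM.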

Compound 4, half-maximal inhibitory concentration: 120 nM
The estimate for compound 4 lay 17-fold (1.22 log units) above the measured number; measured number below the stated range.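

Exchanging 4-(trifluoromethyl)phenyl for 2-(trifluoromethyl)phenyl on the amine nitrogen in a ring gives, in this assay, an at least 8.3-fold lower number from compound 1 to compound 4 (0.92 log units; beyond the scatter). The two compounds have the same atoms, joined differently, so this first readable step in the series shows that where the trifluoromethyl group sits on the phenyl ring is enough on its own to bring a compound from a limit to a measured figure. The full size of the step cannot be read because compound 1 stands at a limit: the limit of > 1000 nM in this assay, at which 1 of the 4 values shown sits.

The compounds shown leave open why the two placements differ, and whether a nitrile or a carboxylic acid in place of the trifluoromethyl group would follow the same course. They also leave open whether the same exchange would carry over to the core of compound 3.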